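A few compounds are considered here, and "the series" means these few. Any claim that something is new, unique, unknown or untested is made for them only; others in the source may bear on it.

Two compounds share one core and differ only in the group carried on a saturated chain carbon bound to an aromatic carbon. Compound 1 `O=C(O)c1ccccc1-c1ccc(CCc2ncc(CC3CCCCC3)[nH]2)cc1` carries cyclohexyl there, and in an in vitro functional assay on cells for agonist activity at Bombesin receptor subtype-3 (Mus musculus), read by luminescence and calcium flux (a lower number here means that less compound is needed, a higher number that more compound is needed for the effect), compound 1 gives 7.3 nM. Going by the values given here, compound 2 `O=C(O)c1ccccc1-c1ccc(CCc2ncc(Cc3ccc(F)cc3)[nH]2)cc1` carries 4-fluorophenyl instead; in this assay compound 2 gives 50 nM, the higher of the two numbers measured so far, the change being a 6.8-fold higher number from compound 1 to compound 2 (0.84 log units; beyond the scatter). Compound 3 `O=C(O)c1ccccc1-c1ccc(CCc2ncc(CC3CCCCCC3)[nH]2)cc1` is not yet measured, and its difference from compound 2 is cycloheptyl in place of 4-fluorophenyl on a saturated chain carbon bound to an aromatic carbon. Among the compounds with values here, the only step that bears on this is a 6.8-fold higher number from compound 1 to compound 2 (0.84 log units; beyond the scatter), where a six-membered aromatic ring replaced a non-aromatic ring of carbon only at the same place and moved the number beyond the scatter. Cycloheptyl is again a non-aromatic ring of carbon only, so given that compound 1 gives 7.3 nM, the expected step is a 4.5-fold lower number from compound 2 to compound 3 (0.66 log units; beyond the scatter), a drop back toward that level. Compound 3 is therefore estimated at 11 nM, likely between 3.5 nM and 35 nM.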

Compound 3, half-maximal effective concentration: 5.7 nM
The estimate for compound 3 lay 1.9-fold (0.29 log units) above the measured number; the measured number falls inside the stated range.
By their numbers in this assay, from the lowest: compounds 3 and 1 (each within the scatter of the next); then compound 2.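

In this assay, a non-aromatic ring of carbon only again gives a low number at this position: cycloheptyl in place of 4-fluorophenyl produces an 8.8-fold lower number from compound 2 to compound 3 (0.94 log units; beyond the scatter), so the earlier gap is not peculiar to cyclohexyl. Enlarging that ring from cyclohexyl to cycloheptyl gives a 1.3-fold lower number from compound 1 to compound 3 (0.11 log units; within the scatter), which means that these two rings cannot be told apart here, while compound 2 stands apart from both. Nothing available explains why these non-aromatic rings and 4-fluorophenyl differ.

As far as these compounds go, it remains open whether the higher number of compound 2 goes with the aromatic ring itself or with its fluorine, a question that plain phenyl would help to separate. From the compounds shown here alone, how far the low numbers extend is also open, for example to cyclopentyl or to an open hexyl chain.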